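The source may hold more compounds than are shown below. What is called first, only, known or untested is meant among the compounds shown, and "the series" means these compounds.

Measured compounds in an assay on brain (strain Sprague-Dawley) for displacement of a labelled ligand from sodium-dependent dopamine transporter (Rattus norvegicus), read by scintillation counting, with a stated time of 120 min; a higher number here means a weaker inhibitor, a lower number a stronger inhibitor:

compound 1, `O=C(CSC(c1ccccc1)c1ccccc1)NCCCc1ccccc1`: 2020 nM
compound 2, `CNC(=O)CSC(c1ccc(Br)cc1)c1ccc(Br)cc1`: 3010 nM
compound 3, `CNC(=O)CSC(c1ccccc1)c1ccccc1`: 19300 nM

Compound 3 carries the smallest amide substituent of the three and gives the highest number, 19300 nM, in this assay. Lengthening that substituent is the one step measured so far: a 9.6-fold lower number from compound 3 to compound 1 (0.98 log units; beyond the scatter). The change is phenethyl in place of hydrogen on a saturated chain carbon bound to an amide-type nitrogen. Compound 2 keeps the small amide substituent of compound 3 but has a different core; the difference between the two cores is not broken down here. The value of compound 2, 3010 nM, and that of compound 1, 2020 nM, lie within the scatter of each other, so nothing can be said about their order.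

Compound 4, `O=C(CSC(c1ccc(Br)cc1)c1ccc(Br)cc1)NCCCc1ccccc1`, is not yet measured. It stands to compound 2 as compound 1 stands to compound 3: the change is phenethyl in place of hydrogen on a saturated chain carbon bound to an amide-type nitrogen, at the same place as before. Within the data shown here, the only guide to its size is the single earlier occurrence, a 9.6-fold lower number from compound 3 to compound 1 (0.98 log units; beyond the scatter), made on the core of compound 3. Whether the core of compound 2 answers in the same way is not known from these three compounds, so the expected step is set near the earlier one but with a wide margin. For compound 4 the step from compound 2 is expected to be a 7.5-fold lower number from compound 2 to compound 4 (0.88 log units; beyond the scatter) in this assay. Compound 4 is accordingly estimated at 400 nM, with a range from 150 nM to 1200 nM.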

Compound 4, inhibition constant: 238 nM
The estimate for compound 4 lay 1.7-fold (0.23 log units) above the measured number; the measured number falls inside the stated range.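

In this assay, phenethyl in place of hydrogen on a saturated chain carbon bound to an amide-type nitrogen again gives a lower number on the core of compound 2, with a 13-fold lower number from compound 2 to compound 4 (1.10 log units; beyond the scatter). The two occurrences agree in direction and do not differ in size beyond what repeated measurement allows: the same change on two cores in this assay, a 9.6-fold lower number (0.98 log units; beyond the scatter) from compound 3 to compound 1 and a 13-fold lower number (1.10 log units; beyond the scatter) from compound 2 to compound 4, 1.3-fold (0.12 log units) apart, within the scatter of two such steps. Among these compounds, this supports carrying the change from one of these cores to the other with about the same effect on the number, but it rests on only two pairs, so it does not establish a rule for other cores, and it gives no explanation for the agreement.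

Still open, as far as these compounds go, is how a shorter or longer chain, an amine or a carboxylic acid would behave in place of 3-phenylpropyl on either core. From the compounds shown here alone, it is also open whether the step depends on the phenyl ring of that group or would persist with a plain alkyl chain, and whether a sulfoxide in place of the thioether sulfur would leave the step unchanged.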